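Core aryl swap: bromo for cyano, compound 3 to compound 4

The source may hold more compounds than are shown below. What is called first, only, known or untested is meant among the compounds shown, and "the series" means these compounds.

Three ureas share one core. Compound 1 `CC(C)N(CCN(C(=O)Nc1cccc(F)c1)C1CC[C@]2(c3cccc(C#N)c3)CC2C1)C(C)C` gives 2.1 nM in a functional assay for antagonist activity at melanin-concentrating hormone receptor 1 (Homo sapiens); a lower number here means a stronger inhibitor, a higher number a weaker inhibitor. Compound 2 `CC(C)N(CCN(C(=O)Nc1cccc(C#N)c1)C1CC[C@]2(c3cccc(C#N)c3)CC2C1)C(C)C` gives 7.6 nM, and compound 3 `CC(C)N(CCN(C(=O)Nc1ccc(F)c(F)c1)C1CC[C@]2(c3cccc(C#N)c3)CC2C1)C(C)C` gives 2.8 nM. Among the three numbers compound 3 sits second highest, with compound 1 nearest and compound 2 furthest. The steps seen so far are a 3.6-fold higher number from compound 1 to compound 2 (0.56 log units; beyond the scatter), a 1.3-fold higher number from compound 1 to compound 3 (0.12 log units; within the scatter) and a 2.7-fold lower number from compound 2 to compound 3 (0.43 log units; beyond the scatter), all on the aryl bound to the amide-type nitrogen.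

Compound 4 `CC(C)N(CCN(C(=O)Nc1ccc(F)c(F)c1)C1CC[C@]2(c3cccc(Br)c3)CC2C1)C(C)C` keeps the 3,4-difluorophenyl urea of compound 3 and changes only the core: bromo in place of cyano on an aromatic carbon. Among the compounds with values here, no measured step alters this ring, so nothing bears on it directly. The nearest comparison, cyano against fluoro on the urea aryl, was a 3.6-fold higher number from compound 1 to compound 2 (0.56 log units; beyond the scatter), a modest move, and cyano against 3,4-difluorophenyl there was a 2.7-fold lower number from compound 2 to compound 3 (0.43 log units; beyond the scatter); halogen and nitrile on that ring stayed within a small span, and a swap on the other ring is taken to behave the same way. The expectation for compound 4 in this assay is therefore no step beyond the scatter, a 1.3-fold higher number from compound 3 to compound 4 (0.10 log units; within the scatter). Compound 4 is estimated at 3.5 nM, within 1.2 nM to 12 nM.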

Compound 4, inhibition constant: 7.76 nM
Compound 4: middle estimate off by 2.2-fold (0.35 log units), on the low side; low and high end bracket the measured number.
By their numbers in this assay, from the lowest: compounds 1 and 3 (each within the scatter of the next); then compounds 2 and 4 (each within the scatter of the next).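

In this assay, within the data shown here, the first change on the core aryl gives a 2.8-fold higher number from compound 3 to compound 4 (0.44 log units; beyond the scatter), a modest step that lies beyond the scatter, so this place on the aromatic ring, meta to a large group, is not indifferent to the swap of cyano for bromo. With the 3,4-difluorophenyl urea held fixed, the nitrile gives the lower number of the two, but this rests on a single matched pair and claims nothing for any other urea aryl. No measurement at hand accounts for the step.

The compounds shown leave open whether bromo in place of cyano gives a step of similar size when the urea aryl is that of compound 1 or compound 2, which would show whether the two sites act independently. They also leave open how hydrogen, chloro, methoxy or a primary amide at the same place would stand against the nitrile and bromo, and so whether any of these matches the number of the cyano compound.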